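Chloro in Place of Acetoxy on Two Different Cores

The compounds below may be only part of what the source reports. "The series", "measured", "known", "first", "only" and "open" are said of these compounds alone.

Compound 1, `CC(=O)OCCc1c(C)[nH]c(=O)[nH]c1=O`, reaches only the limit of > 100000 nM in a functional assay on MCF7 cells (Homo sapiens) for antiproliferative activity, read by MTT assay, with a stated time of 24 h; a higher number here means a weaker inhibitor, a lower number a stronger inhibitor.
Compound 2, `CC(=O)OCCc1c(C)nc(Cl)nc1Cl`, likewise stops at the limit of > 100000 nM in this assay.
Compound 3, `Cc1nc(Cl)nc(Cl)c1CCCl`, gives 8000 nM in this assay.

Compound 2 and compound 3 differ in a single place: chloro in place of acetoxy on a saturated chain carbon, two bonds along the chain from an aromatic carbon. That change produced an at least 12-fold lower number from compound 2 to compound 3 (1.09 log units; beyond the scatter), a step that sets out from the limit of > 100000 nM in this assay, at which 2 of the 3 values shown sit, so its true size is only bounded from below. Compound 4, `Cc1[nH]c(=O)[nH]c(=O)c1CCCl`, is not yet measured; it differs from compound 1 by the same change, (chloro in place of acetoxy on a saturated chain carbon, two bonds along the chain from an aromatic carbon). How the core of compound 1 differs from the core of compound 2 is not broken down here. As far as these compounds go, because the limit of > 100000 nM in this assay, at which 2 of the 3 values shown sit, also caps what compound 1 itself can show, any expectation for compound 4 rests on an at least 12-fold lower number from compound 2 to compound 3 (1.09 log units; beyond the scatter) alone, transferred onto a core whose own behaviour is unknown. Compound 4 is therefore estimated at 60000 nM, with the range 10000 nM to 300000 nM, which is expected to amount to an at least 1.6-fold lower number from compound 1 to compound 4 (0.22 log units; that floor lies within the scatter), and the chance that only a limit is again reported remains substantial.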

Compound 4, half-maximal inhibitory concentration: > 100000 nM
Compound 4: a limit, no number; the forecaster's own chance of this, stated with the estimate: 55%; middle value at least 1.6-fold (0.22 log units) from the limit.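

Compound 4 reaches only the limit of > 100000 nM in this assay. Compound 1 stops at a limit as well, so no step from it to compound 4 can be read: the limit of > 100000 nM in this assay, at which 3 of the 4 values shown sit.

The compounds shown leave open whether chloro in place of acetoxy changes the number at all on the core of compound 1.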